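Ring Swap at the Pyridine Substituent of Compound 3

The compounds below may be only part of what the source reports. "The series", "measured", "known", "first", "only" and "open" are said of these compounds alone.

Measured compounds:
compound 1 `Cc1nc(C(F)(F)F)ccc1CNC(=O)C(C)c1ccc(NS(C)(=O)=O)c(F)c1` gives 387 nM
compound 2 `CCCCCCc1nc(C(F)(F)F)ccc1CNC(=O)C(C)c1ccc(NS(C)(=O)=O)c(F)c1` gives 1.6 nM
compound 3 `CC(C(=O)NCc1ccc(C(F)(F)F)nc1C1CCC(F)(F)CC1)c1ccc(NS(C)(=O)=O)c(F)c1` gives 1.5 nM

In an assay on CHO cells for antagonist activity at transient receptor potential cation channel subfamily V member 1 (Homo sapiens), read by FLIPR and calcium flux (on this read-out higher numbers stand for weaker inhibition and lower numbers for stronger inhibition), compound 3 holds the lowest number of the three, though compound 2 sits within the scatter of it. The large gaps are a 260-fold lower number from compound 1 to compound 3 (2.41 log units; beyond the scatter) and a 240-fold lower number from compound 1 to compound 2 (2.38 log units; beyond the scatter), while a 1.1-fold lower number from compound 2 to compound 3 (0.03 log units; within the scatter) shows that a hexyl chain and a 4,4-difluorocyclohexyl ring give much the same result. Compound 4 `CCC1CC=C(c2nc(C(F)(F)F)ccc2CNC(=O)C(C)c2ccc(NS(C)(=O)=O)c(F)c2)CC1` differs from compound 3 by 4-ethylcyclohex-1-en-1-yl in place of 4,4-difluorocyclohexyl on an aromatic carbon. Both earlier replacements of the small methyl group of compound 1 gave similar numbers, so another group of comparable size is expected to leave the number in place, with a 1.3-fold higher number from compound 3 to compound 4 (0.12 log units; within the scatter) expected to stay within the scatter. Compound 4 is therefore estimated at 2 nM, in the range 0.7 nM to 6 nM.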

Compound 4, inhibition constant: 0.1 nM
Estimate against measurement, compound 4: 20-fold (1.30 log units) above; measured number outside the range, below it.
By their numbers in this assay, from the lowest: compound 4; then compounds 3 and 2 (each within the scatter of the next); then compound 1.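

At this position, on an aromatic carbon next to the ring nitrogen, hexyl and 4,4-difluorocyclohexyl had given matching numbers, but in this assay 4-ethylcyclohex-1-en-1-yl stands apart from both, with a 15-fold lower number from compound 3 to compound 4 (1.18 log units; beyond the scatter) and a 16-fold lower number from compound 2 to compound 4 (1.20 log units; beyond the scatter), so two six-membered non-aromatic rings with the same heavy-atom count need not give the same number. Measured against the methyl group, the change amounts to a 3900-fold lower number from compound 1 to compound 4 (3.59 log units; beyond the scatter). Nothing available accounts for this difference.

The compounds shown leave open whether the ethyl group or the ring double bond carries the change. They also leave open how an amine or a carboxylic acid on the ring would read here.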